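The compounds below may be only part of what the source reports. "The series", "measured", "known", "first", "only" and "open" are said of these compounds alone.

In a functional assay on A2780 cells (Homo sapiens) for antiproliferative activity, read by MTT assay, with a stated time of 48 h (on this read-out higher numbers stand for weaker inhibition and lower numbers for stronger inhibition), compound 1 (`COc1ccc(C(=O)c2ccc(OC)c3c2C=CC(C)(C)O3)c(NC(=O)CBr)c1`) gives 2150 nM and compound 2 (`COc1ccc(C(=O)c2ccc(OC)c3c2C=CC(C)(C)O3)c(NC(=O)CO)c1`) gives 420 nM while compound 3 (`COc1ccc(C(=O)c2ccc(OC)c3c2C=CC(C)(C)O3)c(NC(=O)CN)c1`) gives 890 nM and so stands second highest of the three numbers. Compound 4 (`CNCC(=O)Nc1cc(OC)ccc1C(=O)c1ccc(OC)c2c1C=CC(C)(C)O2`) differs from compound 3 at one place: methyl in place of hydrogen on an amine nitrogen with methyl in place of hydrogen on an amine nitrogen. For the measured compounds named here, no measured step changes that nitrogen by itself. The closest evidence is the exchange of groups on the saturated chain carbon bound to a carbonyl carbon: a 5.1-fold lower number from compound 1 to compound 2 (0.71 log units; beyond the scatter) and a 2.4-fold lower number from compound 1 to compound 3 (0.38 log units; beyond the scatter) and a 2.1-fold higher number from compound 2 to compound 3 (0.33 log units; beyond the scatter) are all modest although beyond the scatter. Each of these replaces a whole group, whereas here the amino group stays and gains one methyl, so a step smaller than a 2.1-fold higher number from compound 2 to compound 3 (0.33 log units; beyond the scatter) is expected, with no clear direction. The step expected is a 1.0-fold higher number from compound 3 to compound 4 (0.00 log units; within the scatter) and it would stay within the scatter. In this assay the estimated value for compound 4 is 900 nM with an expected range (400 nM to 2100 nM).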

Compound 4, half-maximal inhibitory concentration: 1590 nM
The estimate for compound 4 lay 1.8-fold (0.25 log units) below the measured number; measured number inside the range.
By their numbers in this assay, from the lowest: compound 2; then compounds 3, 4 and 1 (each within the scatter of the next, the first and the last beyond it).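

In this assay, methyl in place of hydrogen on the amine nitrogen gives a 1.8-fold higher number from compound 3 to compound 4 (0.25 log units; within the scatter), so this only measured change at that nitrogen does not separate the methylamino compound from the amino compound. Among the groups on the saturated chain carbon, methylamino in place of hydroxy gives a 3.8-fold higher number from compound 2 to compound 4 (0.58 log units; beyond the scatter), which keeps compound 2 apart, while methylamino in place of bromo gives a 1.4-fold lower number from compound 1 to compound 4 (0.13 log units; within the scatter), so compound 4, unlike compound 3, cannot be told apart from compound 1. No measurement at hand accounts for these numbers.

As far as these compounds go, whether dimethylamino, morpholine or a longer chain carrying the amino group would separate from compound 3 stays open. Methoxy in place of hydroxy on the same chain carbon would show whether the number of compound 2 depends on the free hydroxy.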